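From trifluoromethyl to difluoromethyl, with no starting number

The compounds below may be only part of what the source reports. "The series", "measured", "known", "first", "only" and "open" are said of these compounds alone.

Compound 1 `CS(=O)(=O)c1ccc(-n2nc(C(F)F)c(C#N)c2NCC2CC2)cc1`: > 200 ug/mL (a limit of the assay)
Compound 2 `CS(=O)(=O)c1ccc(-n2nc(C(F)F)c(C#N)c2NC2CCCC2)cc1`: 100 ug/mL
Compound 3 `CC(C)(C)CNc1c(C#N)c(C(F)(F)F)nn1-c1ccc(S(C)(=O)=O)cc1`: "not determined" (no result reported)

All three entries come from a physicochemical assay for solubility; on this read-out lower numbers stand for lower solubility and higher numbers for higher solubility. Compound 1 gives > 200 ug/mL, which is a limit and not a number. Compound 3 has no place on the scale, since its entry reads "not determined" (no result reported).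

Compound 4 `CC(C)(C)CNc1c(C#N)c(C(F)F)nn1-c1ccc(S(C)(=O)=O)cc1` is compound 3 with one change hydrogen in place of fluoro on a saturated chain carbon bound to an aromatic carbon and two fluorine atoms, or trifluoromethyl to difluoromethyl.

Within the data shown here, the only measured step is an at least 2.0-fold lower number from compound 1 to compound 2 (0.30 log units; that floor lies within the scatter). It is a different change, cyclopentyl in place of cyclopropylmethyl on a nitrogen on an aromatic ring, so it does not bear directly on this one. With no measured trifluoromethyl to difluoromethyl step and no number for compound 3, no particular size or direction of step can be expected in this assay.

Among the measured compounds shown here, the estimate therefore leans on compound 2 at 100 ug/mL, the only plain number measured, and the range is kept wide. For compound 4 the expected value is 80 ug/mL, with an estimated range of 25 ug/mL to 220 ug/mL.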

Compound 4, solubility: > 200 ug/mL
Compound 4 gave a limit, no number; the forecaster's own chance of this, stated with the estimate: 20%; at least 2.5-fold (0.39 log units) between middle value and limit.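

In this assay compound 4 gives > 200 ug/mL, which is a limit of the assay and not a number. Among these compounds, this is the first reading for a neopentyl group on the nitrogen, since compound 3 carries the same group but has no reported result, and swapping the cyclopentyl group of the shared core for neopentyl gives an at least 2.0-fold higher number from compound 2 to compound 4 (0.30 log units; that floor lies within the scatter); with only a floor inside the scatter, this step does not firmly set compound 4 apart from compound 2. The step between compound 1 and compound 4 cannot be read, because both entries are limits and the top of the scale hides any order between them: the limit of > 200 ug/mL in this assay, at which 2 of the 4 values shown sit.

From the compounds shown here alone, the effect of going from trifluoromethyl to difluoromethyl remains open, as compound 3 offers no reading to compare with compound 4. Also open, going by these compounds, is whether a methyl group in place of difluoromethyl, or a longer chain or an amine on the nitrogen, would give a plain number on this scale.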